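Urea aryl swap: dichlorophenyl to trifluoromethylphenyl

This account rests on a few compounds, and the source may have more. Where it says the series, first, only, none or still open, it means among the compounds named here.

The series shares one core and varies the group on the amide-type nitrogen. Compound 1 `COc1cc(-c2nn(-c3cccc(NC(=O)Nc4cc(C(F)(F)F)cc(C(F)(F)F)c4)c3)cc2-c2ccncc2)ccc1Cl` carries a bis(trifluoromethyl)phenyl urea; in a functional assay on KM12 cells (Homo sapiens) for inhibition, read by sulforhodamine B assay, with a stated time of 48 h (on this read-out lower numbers stand for stronger inhibition of growth and higher numbers for weaker inhibition of growth), compound 1 gives 1340 nM. Compound 2 `COc1cc(-c2nn(-c3cccc(NC(=O)c4cccc(C(F)(F)F)c4)c3)cc2-c2ccncc2)ccc1Cl` is the benzamide; in this assay compound 2 gives only a limit, > 50000 nM. Compound 3 `COc1cc(-c2nn(-c3cccc(NC(=O)Nc4ccc(Cl)c(Cl)c4)c3)cc2-c2ccncc2)ccc1Cl` is the dichlorophenyl urea, and in this assay compound 3 gives 2770 nM, the higher of the two numbers, with compound 1 the nearer.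

Compound 4 `COc1cc(-c2nn(-c3cccc(NC(=O)Nc4cccc(C(F)(F)F)c4)c3)cc2-c2ccncc2)ccc1Cl` keeps the urea and changes the aryl group: 3-(trifluoromethyl)phenyl in place of 3,4-dichlorophenyl on an amide-type nitrogen.

Among the compounds with values here, one measured step touches this region: an at least 18-fold lower number from compound 2 to compound 3 (1.25 log units; beyond the scatter), but it swaps amide for urea together with the aryl, so it speaks to the urea rather than to the aryl swap. Compound 1 and compound 3 show that a trifluoromethyl-bearing aryl on the urea sits at the lower number of the two. For compound 4 a modest step downward is expected, a 1.5-fold lower number from compound 3 to compound 4 (0.19 log units; within the scatter), giving an estimate of 1800 nM with a range from 700 nM to 5000 nM.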

Compound 4, concentration for total growth inhibition: 1980 nM
Beside the measured number, compound 4's estimate is 1.1-fold (0.04 log units) below it, within the range that was stated.
By their numbers in this assay, from the lowest: compounds 1, 4 and 3 (each within the scatter of the next, the first and the last beyond it). At a limit, above all of these: compound 2.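

In this assay the change from amide to urea can now be read with the aryl group held as 3-(trifluoromethyl)phenyl (an at least 25-fold lower number from compound 2 to compound 4 (1.40 log units; beyond the scatter)), so the urea effect no longer rests on a step that also swaps the aryl. On the urea, neither 3-(trifluoromethyl)phenyl in place of 3,4-dichlorophenyl (a 1.4-fold lower number from compound 3 to compound 4 (0.15 log units; within the scatter)) nor hydrogen in place of one trifluoromethyl (a 1.5-fold higher number from compound 1 to compound 4 (0.17 log units; within the scatter)) moves the number beyond the scatter, so these three aryl groups are not told apart here. The value of compound 2 is a limit, not a number: the limit of > 50000 nM in this assay, at which 1 of the 4 values shown sits.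

Open, going by these compounds, is whether an aryl urea carrying an amine or a carboxylic acid, or a longer alkyl chain in place of the aryl, stays in this range. Also open, on these data alone, is whether the urea gain holds on any core other than the shared one.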